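The source may report more compounds than this note shows. Statements on the series, on what has been measured and on what is new or still open speak of the compounds shown alone.

In an ADME assay on microsomes from liver (Rattus norvegicus) for metabolic stability, read by LC-MS, using NADPH, with a stated time of 30 min, tested at 0.1 uM (a lower number here means that less of the compound is left, a higher number that more of the compound is left), compound 1 `O=S(=O)(NCC1COC1)c1cccc(-c2ccc3nccc(-c4ccncc4)c3n2)c1` gives 8% and stands lowest of the two numbers at hand, while compound 2 `O=S(=O)(NCCO)c1cccc(Nc2ccc3nccc(-c4ccncc4)c3n2)c1` gives 58% and the gap between them lies beyond the scatter. Compound 3 `O=S(=O)(c1cccc(-c2ccc3nccc(-c4ccncc4)c3n2)c1)N1CC[C@H](O)C1` has not yet been measured. It has the same atoms as compound 1, joined differently: 3-hydroxypyrrolidin-1-yl in place of ((oxetan-3-yl)methyl)amino on a sulfonyl sulfur sums up the change, with 3-hydroxypyrrolidin-1-yl in place of ((oxetan-3-yl)methyl)amino on a sulfonyl sulfur. The entering group also has 1 defined stereocentre. Within the data shown here, no measured pair isolates this change, so the expectation rests on little. Compound 1 at 8% leaves nearly all the room upward, and the expected step of a number 12 percentage points higher from compound 1 to compound 3 (beyond the scatter) in this assay is a modest rise. In this assay the estimate for compound 3 is 20% with an expected range from 5% to 45% and the measurement still to come.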

Compound 3, percent of the compound remaining: 10%
For compound 3 the middle estimate is 10 percentage points above the measured one, within the range that was stated.
By their numbers in this assay, from the lowest: compounds 1 and 3 (each within the scatter of the next); then compound 2.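

Putting 3-hydroxypyrrolidin-1-yl in place of ((oxetan-3-yl)methyl)amino on a sulfonyl sulfur gives in this assay a step of a number 2 percentage points higher from compound 1 to compound 3 (within the scatter) and so separates neither compound from the other. At this position, then, a five-membered non-aromatic ring carrying a defined stereocentre reads the same as a four-membered non-aromatic ring on a short chain, with both groups holding the same heavy atoms. Both compounds sit low in this read-out, so the pair shows that this reshuffling of atoms on the sulfonyl sulfur leaves the number within the scatter. Still open, going by these compounds, is how a group of another kind on that sulfur, such as a simple dimethylamino group or a longer chain ending in a carboxylic acid, would read here. Nothing at hand explains the result or speaks to a cause for it.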